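A few compounds are considered here, and "the series" means these few. Any claim that something is new, unique, unknown or untested is made for them only; others in the source may bear on it.

Compound 1 `CC(C)n1ccc2c(C(=O)Nc3ccc(F)cc3)cc(-c3cccs3)nc21` gives > 200000 nM in an ADME assay on LLC-MK2 cells (Macaca mulatta) for cytotoxicity, read by spectrophotometry and crystal violet staining, with a stated time of 4 days; on this read-out higher numbers stand for lower toxicity in this test and lower numbers for higher toxicity in this test; this value is a limit of the test, not a number.
Compound 2 `CC(C)n1ncc2c(C(=O)Nc3c(F)cc(F)cc3F)cc(-c3cccs3)nc21` gives > 200000 nM in this assay, again a limit.
Compound 3 `CC(C)n1ncc2c(C(=O)Nc3ccccc3F)cc(-c3ccccc3)nc21` gives > 200000 nM in this assay, also a limit.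

Compound 2 therefore stands at the limit of > 200000 nM in this assay, at which 3 of the 3 values shown sit, with no number of its own. Compound 4 `CC(C)n1ncc2c(C(=O)Nc3ccc(F)cc3F)cc(-c3cccs3)nc21` differs from compound 2 by hydrogen in place of fluoro on an aromatic carbon, the change reading 2,4,6-trifluorophenyl to 2,4-difluorophenyl. Going by the values given here, with no measured step between these compounds, no change beyond the usual scatter is expected in this assay, so the step that the limit leaves unreadable from compound 2 to compound 4 is expected to be small. Compound 4 is estimated at 300000 nM, between 150000 nM and 1000000 nM, most likely reported as a limit like compound 2.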

Compound 4, half-maximal cytotoxic concentration: > 200000 nM
Compound 4 ended at the assay's limit; the forecaster's own chance of this, stated with the estimate: 85%; the middle value lies beyond the limit too.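

In this assay compound 4 gives > 200000 nM, a limit. Going by these compounds alone, compound 2 also sits at a limit, so no step between compound 2 and compound 4 can be read. The compounds shown leave open what concentration, if any, would reach half-maximal cytotoxicity.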